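This account rests on a few compounds, and the source may have more. Where it says the series, first, only, none or still open, it means among the compounds named here.

Working notes on the series.

Compound 1 `CCCSc1nc(Cc2c(F)cccc2Cl)c(C)c(=O)[nH]1` carries a propylthio group on the shared core. In an ADME assay on MT4 cells (Homo sapiens) for activation, read by MTT assay (a lower number here means that less compound is tolerated, a higher number that more compound is tolerated), compound 1 gives > 76000 nM, which is a limit of the assay and not a number. Compound 2 `CCCCSc1nc(Cc2c(F)cccc2Cl)c(C)c(=O)[nH]1` differs from it by methyl in place of hydrogen on a saturated chain carbon, three bonds along the chain from a sulfur. In this assay compound 2 gives > 73000 nM, again only a limit. The step that the two limits leave unreadable from compound 1 to compound 2 therefore cannot be read, as the limit of > 76000 nM in this assay, at which 1 of the 3 values shown sits, and the limit of > 73000 nM in this assay, at which 1 of the 3 values shown sits, leave no gap to measure.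

Compound 3 `Cc1c(C(C)c2c(F)cccc2Cl)nc(SC(C)C)[nH]c1=O` is built on a core whose difference from the core of compound 1 is not broken down here. In this assay compound 3 gives > 15000 nM, a limit only, as the limit of > 15000 nM in this assay, at which 1 of the 3 values shown sits, records.

Compound 4 `CCC(c1nc(SC(C)C)[nH]c(=O)c1C)c1c(F)cccc1Cl`, not yet measured, differs from compound 3 by methyl in place of hydrogen on a saturated chain carbon, two bonds along the chain from two aromatic carbons. This is the same kind of change as that from compound 1 to compound 2, but the place differs: there the carbon sits three bonds along the chain from a sulfur, here two bonds along the chain from two aromatic carbons.

For compound 4 in this assay the expected step is a step that the limit leaves unreadable from compound 3 to compound 4, resting on the fact that compound 3 gives > 15000 nM and compound 1 gives > 76000 nM, both limits, and that the step that the two limits leave unreadable from compound 1 to compound 2 shows no readable movement. Compound 4 is estimated at 40000 nM, most likely to be reported as a limit, with a range from 15000 nM to 100000 nM.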

Compound 4, half-maximal cytotoxic concentration: > 3000 nM
Compound 4: only a limit was reported (the forecaster's own chance of this, stated with the estimate: 80%); the middle value does not contradict the limit.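

In this assay compound 3 and compound 4 both give only limits of the assay, so no step can be read between them: the limit of > 3000 nM in this assay, at which 1 of the 4 values shown sits.

The compounds shown leave open where the actual half-maximal cytotoxic concentrations of compound 1 to compound 4 lie, and whether methyl in place of hydrogen moves them at either place.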